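Chromatographic lipophilicity notes: compound 3 toward compound 4

A few compounds are considered here, and "the series" means these few. Any claim that something is new, unique, unknown or untested is made for them only; others in the source may bear on it.

Three compounds have a reading in a physicochemical assay for lipophilicity, read by HPLC, in phosphate buffer, measured as chromatographic lipophilicity, at pH 7.4; on this read-out lower numbers stand for lower lipophilicity and higher numbers for higher lipophilicity. Compound 1 `Cc1cc(C)cc(NC(=O)COc2cc(C)nc3ccc(OC(F)(F)F)cc23)c1` gives 6.79 and compound 2 `CCCc1cc(OCC(=O)Nc2cc(C)cc(C)c2)c2cc(OC)ccc2n1` gives 6.44. Compound 3 `COc1ccc2nc(C)cc(OCC(=O)Nc3ccccc3)c2c1` gives 4.28, the lowest of the three; the nearest number is that of compound 2 and the furthest that of compound 1, both gaps lying beyond the scatter. Compound 4 `COc1ccc2nc(C)cc(OCC(=O)Nc3c(C)cncc3C)c2c1` has not been measured. It differs from compound 3 in one place: 3,5-dimethylpyridin-4-yl in place of phenyl on an amide-type nitrogen. Among the measured compounds shown here, no measured pair isolates this change, so nothing measured fixes the direction of the step. In this assay the step expected here, a number 0.08 log units lower from compound 3 to compound 4 (within the scatter), is small, within the scatter, with no clear direction. Compound 4 is accordingly estimated at 4.2, with a range from 3.5 to 4.9.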

Compound 4, distribution coefficient: 3.01
Compound 4: the middle estimate sits 1.19 log units above what was measured, outside the stated range (below it).
By their numbers in this assay, from the lowest: compound 4; then compound 3; then compound 2; then compound 1.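

In this assay, 3,5-dimethylpyridin-4-yl in place of phenyl on an amide-type nitrogen gives a number 1.27 log units lower from compound 3 to compound 4 (beyond the scatter). Among the compounds shown here, this is the first single-place step, and it shows that the read-out can respond strongly to a change at this position. No measurement shown accounts for the size or direction of this step.

The ring nitrogen and the two methyl groups enter together, and the compounds shown do not separate their contributions. A plain pyridin-4-yl on the same amide-type nitrogen, with the rest of compound 3 kept, would address that question.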